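The source may report more compounds than this note shows. Statements on the series, on what has been measured and on what is new or still open speak of the compounds shown alone.

Working notes on the chloroalkanamide series.

Three compounds have been run in a functional assay on MCF7 cells (Homo sapiens) for antiproliferative activity, with a stated time of 48 h; on this read-out higher numbers stand for weaker inhibition and lower numbers for stronger inhibition. Compound 1 `O=C(CCl)Nc1ccc(I)cc1` gives 6200 nM. Compound 2 `O=C(CCCl)Nc1ccc(I)cc1` gives 26000 nM. Compound 3 `CC(C)(C)c1ccc(CNC(=O)CCCl)cc1` gives 67000 nM, the highest number of the three.

Among the compounds with values here, the single change from compound 1 to compound 2 is chloromethyl in place of chloro on a saturated chain carbon bound to a carbonyl carbon; it gave a 4.2-fold higher number from compound 1 to compound 2 (0.62 log units; beyond the scatter). Compound 3 and compound 1 differ in their cores; that difference is not broken down here.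

Compound 4 `CC(C)(C)c1ccc(CNC(=O)CCCCl)cc1` is the next candidate. It differs from compound 3 by chloromethyl in place of chloro on a saturated chain carbon, two bonds along the chain from a carbonyl carbon. This is the same kind of change as that from compound 1 to compound 2, but the place is not identical: there the change sat on a saturated chain carbon bound to a carbonyl carbon, whereas here it sits on a saturated chain carbon, two bonds along the chain from a carbonyl carbon.

Within the data shown here, the step from compound 3 to compound 4 in this assay is expected to be a 3.0-fold higher number from compound 3 to compound 4 (0.47 log units; beyond the scatter), resting on the one precedent, because a 4.2-fold higher number from compound 1 to compound 2 (0.62 log units; beyond the scatter) ran in the weaker direction. Compound 4 is thus estimated at 200000 nM, with a likely range from 70000 nM to 600000 nM.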

Compound 4, half-maximal inhibitory concentration: 92000 nM
Estimate against measurement, compound 4: 2.2-fold (0.34 log units) above, and the stated range covers the measured number.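

In this assay, the new step reads a 1.4-fold higher number from compound 3 to compound 4 (0.14 log units; within the scatter), so compound 3 and compound 4 cannot be told apart on this read-out, whereas the same kind of change on the core of compound 1 gave a 4.2-fold higher number from compound 1 to compound 2 (0.62 log units; beyond the scatter). The size of the step therefore does not carry over from one core to the other in this pair of examples: the same change on two cores in this assay, a 4.2-fold higher number (0.62 log units; beyond the scatter) from compound 1 to compound 2 and a 1.4-fold higher number (0.14 log units; within the scatter) from compound 3 to compound 4, 3.1-fold (0.48 log units) apart, beyond the scatter of two such steps. This does not show that the core alone sets the size of the step, since the two changes also sit at different places on the chain, and a single step on each core gives no general rule for the series.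

The compounds shown leave open how the core of compound 1 behaves with a 3-chloropropyl carbonyl chain, the comparison that would separate core from place. They also leave open whether a longer chain, or an amine in place of the terminal chloro, would keep the activity seen with these chains.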